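Shuffling the Chlorines on the Piperazine Aryl Group

The source may report more compounds than this note shows. Statements on the series, on what has been measured and on what is new or still open speak of the compounds shown alone.

Three compounds share a core and differ only in the aryl group on an amine nitrogen in a ring. In a functional assay on CHO cells with adenosine receptor A1 (Homo sapiens) as the target, read by cAMP accumulation and immunoassay, with a stated time of 6 min, tested at 10 uM (on this read-out lower numbers stand for a stronger effect and higher numbers for a weaker effect at the one concentration tested), compound 1 `Nc1scc(CN2CCN(c3cccc(F)c3)CC2)c1C(=O)c1ccc(Cl)cc1` gives -82%, and compound 2 `Nc1scc(CN2CCN(c3ccc(F)cc3F)CC2)c1C(=O)c1ccc(Cl)cc1` gives -82%, with no change at the digits printed from compound 1 to compound 2 (within the scatter). Compound 3 `Nc1scc(CN2CCN(c3cc(Cl)ccc3Cl)CC2)c1C(=O)c1ccc(Cl)cc1` gives -62%, the highest of the three numbers, so the weakest effect here: a number 20 percentage points higher from compound 1 to compound 3 (beyond the scatter) and a number 20 percentage points higher from compound 2 to compound 3 (beyond the scatter).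

Compound 4 `Nc1scc(CN2CCN(c3ccc(Cl)c(Cl)c3)CC2)c1C(=O)c1ccc(Cl)cc1` is the next step: 3,4-dichlorophenyl in place of 2,5-dichlorophenyl on an amine nitrogen in a ring. Going by the values given here, no measured step moves a chlorine from one position of the ring to another, so nothing bears on it directly. The two steps that reach compound 3 show that a dichlorophenyl can sit above the fluorophenyls, but whether that holds for the new arrangement is open. The estimate for compound 4 therefore leans toward the span between the groups, with a step of a number 10 percentage points lower from compound 3 to compound 4 (within the scatter) expected, that is a somewhat stronger effect than compound 3. Compound 4 is thus expected to give -72%, within -88% to -55%.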

Compound 4, a percentage reported as activity, at one concentration (the size of the read-out at that concentration, not a potency): -62%
Compound 4: middle estimate off by 10 percentage points, on the low side; measured number inside the range.
By their numbers in this assay, from the lowest: compounds 1 and 2 (each within the scatter of the next); then compounds 3 and 4 (each within the scatter of the next).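

In this assay the change from 2,5-dichlorophenyl to 3,4-dichlorophenyl on the amine nitrogen in a ring brings no change at the digits printed from compound 3 to compound 4 (within the scatter) and is the only step shown that rearranges the same two chlorines, so this rearrangement leaves the read-out where it was. The gap to the fluorinated aryl groups holds for this second dichlorophenyl, with a number 20 percentage points higher from compound 2 to compound 4 (beyond the scatter) and a number 20 percentage points higher from compound 1 to compound 4 (beyond the scatter) as well, so compound 3 is no longer alone in standing apart from compound 1 and compound 2. Nothing available explains why the two chlorine arrangements read alike or why they part from the fluorinated groups.

As far as these compounds go, whether a 4-chlorophenyl with a single chlorine would read with the dichlorophenyls or with the fluorinated groups stays open. So does the outcome for a methoxyphenyl or a pyridine ring on the same nitrogen.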